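This account rests on a few compounds, and the source may have more. Where it says the series, first, only, none or still open, it means among the compounds named here.

Values in a functional assay on HepG2 cells (Homo sapiens) for cytotoxicity, read by MTT assay, with a stated time of 48 h (a lower number here means a stronger inhibitor, a higher number a weaker inhibitor), for the measured members of the series:

compound 1 `COc1cc(-c2nnc3n2NC(c2ccco2)C(C(=O)c2cccs2)S3)cc(OC)c1OC`: 64100 nM
compound 2 `COc1cc(-c2nnc3n2NC(c2ccco2)C(C(=O)c2ccc(F)cc2)S3)cc(OC)c1OC`: > 100000 nM, a limit of the assay
compound 3 `COc1cc(-c2nnc3n2NC(c2ccco2)C(C(=O)C2CC2)S3)cc(OC)c1OC`: > 100000 nM, a limit of the assay

Compound 2 stands at the limit of this assay; its value is not a number. Compound 3 also sits at that limit, so that two of the three values shown are the limit of > 100000 nM in this assay, at which 2 of the 3 values shown sit. Only compound 1 returns a number in this assay. The three measured steps all lie on the carbonyl carbon: an at least 1.5-fold higher number from compound 1 to compound 2 (0.19 log units; that floor lies within the scatter), an at least 1.5-fold higher number from compound 1 to compound 3 (0.19 log units; that floor lies within the scatter), and a step that the two limits leave unreadable from compound 2 to compound 3.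

Compound 4 `COc1cc(-c2nnc3n2NC(c2cccs2)C(C(=O)c2ccc(F)cc2)S3)cc(OC)c1OC` differs from compound 2 at a different place: thiophen-2-yl in place of furan-2-yl on a saturated ring carbon. For the measured compounds named here, no measured step touches the saturated ring carbon, so nothing in the set speaks directly to this exchange. Going by the values given here, the shared core with a (4-fluorophenyl)carbonyl group gave only a limit for compound 2, and the one exchange between five-membered aromatic rings that has been measured, from thiophen-2-yl to 4-fluorophenyl on the carbonyl carbon, stayed within the scatter at its floor. The expectation is therefore a step of a number no higher from compound 2 to compound 4 (the limit leaves the size open) in this assay, that is none beyond the scatter, with a fair chance that compound 4 again returns only a limit. The estimate for compound 4 in this assay is 100000 nM, within 40000 nM to 300000 nM.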

Compound 4, half-maximal inhibitory concentration: 54200 nM
Compound 4: the middle estimate sits 1.8-fold (0.27 log units) above what was measured; low and high end bracket the measured number.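

In this assay the saturated ring carbon now has its first measured exchange: thiophen-2-yl in place of furan-2-yl gives an at least 1.8-fold lower number from compound 2 to compound 4 (0.26 log units; that floor lies within the scatter) with the (4-fluorophenyl)carbonyl group held constant. For the compounds shown here, compound 4 thus returns a number with a carbonyl partner that had so far given only a limit, so the carbonyl carbon is no longer the only place where a change separates a limit from a number. The size of this step remains a floor, not a measured difference, because one end of it is a limit rather than a number: the limit of > 100000 nM in this assay, at which 2 of the 4 values shown sit.

From the compounds shown here alone, whether the true step lies beyond the scatter cannot be read from these values, and it remains open whether the same exchange on the saturated ring carbon carries over to the compounds with a thiophen-2-yl or cyclopropyl group on the carbonyl carbon. Also open, going by these compounds, is how this carbon responds to groups other than five-membered aromatic rings, such as a plain phenyl ring, a cyclohexyl ring, or a short chain ending in an amine or a carboxylic acid.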